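The source may report more compounds than this note shows. Statements on the series, on what has been measured and on what is new or still open speak of the compounds shown alone.

Measured so far:

Compound 1, `CCc1nc2nc(C)cc(Nc3ccc(Cl)cc3)n2n1`: in a physicochemical assay for lipophilicity, at pH 7.4 (on this read-out higher numbers stand for higher lipophilicity and lower numbers for lower lipophilicity), compound 1 gives 2.8.
Compound 2, `Cc1cc(Nc2ccc(S(F)(F)(F)(F)F)cc2)n2nc(C(C)(F)F)nc2n1`: in this assay compound 2 gives 3.6.
Compound 3, `CCC(F)(F)c1nc2nc(C)cc(Nc3ccc(S(F)(F)(F)(F)F)cc3)n2n1`: in this assay compound 3 gives 3.9.

Compound 1 has the lowest value of the measured set; its value against that of compound 2 shows a gap that is beyond the usual scatter, and the gap to compound 3 is larger still. The difference between the core of compound 1 and the core of compound 2 is not broken down here.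

Among the measured compounds shown here, the one change that is measured as a single step is methyl in place of hydrogen on a saturated chain carbon, two bonds along the chain from an aromatic carbon and two fluorine atoms. Here compound 2 and compound 3 differ, and the step was a number 0.30 log units higher from compound 2 to compound 3 (within the scatter).

Compound 4, `Cc1cc(Nc2ccc(Cl)cc2)n2nc(C(C)C)nc2n1`, has not yet been measured. It differs from compound 1 by methyl in place of hydrogen on a saturated chain carbon bound to an aromatic carbon and a saturated chain carbon. For the measured compounds named here, this is the same kind of change as the one from compound 2 to compound 3, not the same: in compound 4 the methyl enters on a saturated chain carbon bound to an aromatic carbon and a saturated chain carbon, whereas in compound 3 it entered on a saturated chain carbon two bonds along the chain from an aromatic carbon and two fluorine atoms.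

Because the measured step was a number 0.30 log units higher from compound 2 to compound 3 (within the scatter), compound 4 is expected to move from compound 1 by about a number 0.40 log units higher from compound 1 to compound 4 (beyond the scatter). In this assay compound 4 is therefore estimated at 3.2, expected to lie between 2.9 and 3.6.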

Compound 4, distribution coefficient: 3.2
Compound 4: middle estimate and measured number agree at the digits printed; the range from low to high includes it.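

In this assay, the change from ethyl to isopropyl, which is methyl in place of hydrogen on a saturated chain carbon bound to an aromatic carbon and a saturated chain carbon, gives a number 0.40 log units higher from compound 1 to compound 4 (beyond the scatter), while the related methyl change on the other core, on a saturated chain carbon two bonds along the chain from an aromatic carbon and two fluorine atoms, gives a number 0.30 log units higher from compound 2 to compound 3 (within the scatter). Only the first of these steps stands clear of the scatter, and the second cannot be told apart from no change, so the two pairs do not establish that this methyl change carries the same result from one core to the other. The two steps differ both in the core and in the carbon that takes the methyl, these pairs cannot separate those two differences, and no measurement is available that explains the size of either step.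

Still open, on these data alone, is how the same position behaves with a butyl group, a cyclopropyl ring or an amine in place of the isopropyl of compound 4. The compounds shown also leave open whether the ethyl to isopropyl change would give a similar step on the core of compound 2, or on any further core.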